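Methoxy in Place of Hydrogen Across Two Cores

The source may hold more compounds than are shown below. What is called first, only, known or untested is meant among the compounds shown, and "the series" means these compounds.

Measured compounds and values:
compound 1 `Cc1cc(=O)oc2ccc(OCC(O)CN3CCN(c4ccccc4)CC3)cc12`: 0.0052 ug/mL
compound 2 `COc1ccccc1N1CCN(CC(O)COc2ccc3oc(=O)cc(C)c3c2)CC1`: 0.0058 ug/mL
compound 3 `O=c1cc(-c2ccccc2)c2ccc(OCC(O)CN3CCN(c4ccccc4)CC3)cc2o1`: 0.0054 ug/mL

All three were tested in a functional assay on ileum for antagonist activity at histamine H1 receptor (Cavia porcellus), tested at 0.1 mg/mL; a higher number here means that more compound is needed for the effect, a lower number that less compound is needed. Compound 2 differs from compound 1 by methoxy in place of hydrogen on an aromatic carbon, and that step gave a 1.1-fold higher number from compound 1 to compound 2 (0.05 log units; within the scatter). Compound 3 shares the change-site with compound 1, but the difference between the two cores is not broken down here. Compound 4 `COc1ccccc1N1CCN(CC(O)COc2ccc3c(-c4ccccc4)cc(=O)oc3c2)CC1` differs from compound 3 by methoxy in place of hydrogen on an aromatic carbon, the same change as between compound 1 and compound 2, at a place described in identical words. The step from compound 3 to compound 4 is therefore expected to be a 1.1-fold higher number from compound 3 to compound 4 (0.05 log units; within the scatter) in this assay, because the earlier step gave a 1.1-fold higher number from compound 1 to compound 2 (0.05 log units; within the scatter). Compound 4 is accordingly estimated at 0.006 ug/mL, with a likely range from 0.003 ug/mL to 0.012 ug/mL.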

Compound 4, half-maximal effective concentration: 0.0057 ug/mL
The estimate for compound 4 lay 1.1-fold (0.02 log units) above the measured number; low and high end bracket the measured number.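

In this assay, methoxy in place of hydrogen on an aromatic carbon gave a 1.1-fold higher number from compound 3 to compound 4 (0.02 log units; within the scatter), and this step agrees with the earlier one on the other core: the same change on two cores in this assay, a 1.1-fold higher number (0.05 log units; within the scatter) from compound 1 to compound 2 and a 1.1-fold higher number (0.02 log units; within the scatter) from compound 3 to compound 4, 1.1-fold (0.02 log units) apart, within the scatter of two such steps. The change therefore carried from the core of compound 1 to the core of compound 3 with no difference that can be told from the scatter, and neither step stands beyond it. Two steps this small are only a weak test, however: they show that the change made no visible difference on either core, not that a real effect of the change would carry over.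

Going by these compounds, it remains open whether a nitrile or a chlorine in place of the methoxy, or a longer chain linking the core to the rest of the molecule, would give a step beyond the scatter. On these data alone, it also remains open whether the agreement would hold on a third core.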